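A few compounds are considered here, and "the series" means these few. Any claim that something is new, unique, unknown or untested is made for them only; others in the source may bear on it.

Measured so far:
Compound 1, `Cc1noc(NS(=O)(=O)c2cccc3c(N(C)C)cccc23)c1-c1ccccc1`: 15900 nM
Compound 2, `Cc1onc(NS(=O)(=O)c2cccc3c(N(C)C)cccc23)c1C`: 60 nM
Compound 3, `Cc1noc(NS(=O)(=O)c2cccc3c(N(C)C)cccc23)c1Cc1ccccc1`: 50000 nM

In an assay on VSM-A10 cells for antagonist activity at Endothelin-1 receptor (Rattus norvegicus) (on this read-out higher numbers stand for weaker inhibition and lower numbers for stronger inhibition), compound 3 gives 50000 nM, the highest of the three numbers; compound 1 gives 15900 nM and compound 2 gives 60 nM. Within the data shown here, the only measured step between neighbours, a 3.1-fold higher number from compound 1 to compound 3 (0.50 log units; beyond the scatter), shows that the larger group on that aromatic carbon went with a higher number. Compound 4, `Cc1noc(NS(=O)(=O)c2cccc3c(N(C)C)cccc23)c1[N+](=O)[O-]`, differs from compound 3 in that (nitro in place of benzyl on an aromatic carbon). Among the measured compounds shown here, no measured step involves a nitro, so the expectation rests on size alone: the values of compound 2 and compound 3 show that a methyl on that carbon sits far below a benzyl, and nitro is likewise a small group. For the measured compounds named here, compound 4 is therefore expected to move strongly in the direction of compound 2, a step of a 170-fold lower number from compound 3 to compound 4 (2.22 log units; beyond the scatter) in this assay, though with wide uncertainty since nitro has no precedent here. The estimate for compound 4 in this assay is 300 nM, with a range from 40 nM to 3000 nM.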

Compound 4, half-maximal inhibitory concentration: 17300 nM
The estimate for compound 4 lay 58-fold (1.76 log units) below the measured number; the measured number lies above the stated range.
By their numbers in this assay, from the lowest: compound 2; then compounds 1 and 4 (each within the scatter of the next); then compound 3.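

In this assay the exchange of benzyl for nitro on this aromatic carbon gives only a 2.9-fold lower number from compound 3 to compound 4 (0.46 log units; beyond the scatter) even though nitro has three heavy atoms and no ring against the seven heavy atoms and ring of benzyl. Nitro and phenyl cannot be told apart at this position, with a 1.1-fold higher number from compound 1 to compound 4 (0.04 log units; within the scatter) so among compounds 1, 3 and 4 a smaller group does not by itself bring a much lower number. Nothing available explains this result.

Compound 2 differs from these compounds in more than one place, so its number does not speak to this position. From the compounds shown here alone, whether an amine or a carboxylic acid on this carbon would give a much lower number remains open, as does the effect of a methyl there on the core of compound 1.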